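From Methoxy to Azetidin-1-yl: What Efficacy to Expect

The source may hold more compounds than are shown below. What is called first, only, known or untested is meant among the compounds shown, and "the series" means these compounds.

Among the measured compounds shown here, compound 1 `COc1cc(-c2nc(C(c3ccc(F)cc3)c3ccc(F)cc3)sc2CC(=O)O)ccn1` reaches 60% in an in vitro functional assay on HEK285-7 cells for antagonist activity at prostaglandin D2 receptor 2 (Homo sapiens), read by BRET and beta-arrestin recruitment (on this read-out higher numbers stand for larger maximal responses and lower numbers for smaller maximal responses), one of only two numbers known here, and the other lies within the usual scatter of it. Compound 2 `CCC(c1ccccc1)c1nc(-c2ccc(Cl)cc2)c(CC(=O)O)s1` reaches 50% in this assay. For the measured compounds named here, no pair of measured compounds differs in just one place, so no measured step guides the next change. Compound 3 `O=C(O)Cc1sc(C(c2ccc(F)cc2)c2ccc(F)cc2)nc1-c1ccnc(N2CCC2)c1` differs from compound 1 in one place: azetidin-1-yl in place of methoxy on an aromatic carbon. With nothing comparable to lean on, the step of no change at the digits printed from compound 1 to compound 3 (within the scatter) is expected to stay within the scatter. Compound 3 is therefore estimated at 60%, between 40% and 80%.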

Compound 3, largest response reached (reported as efficacy), in percent of the reference or control that the assay uses: 80%
The estimate for compound 3 lay 20 percentage points below the measured number, within the range that was stated.
By their numbers in this assay, from the lowest: compounds 2 and 1 (each within the scatter of the next); then compound 3.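

Azetidin-1-yl in place of methoxy on an aromatic carbon, next to the ring nitrogen, gives a number 20 percentage points higher from compound 1 to compound 3 (beyond the scatter) in this assay. Among the compounds shown here, this is the first measured step between compounds that differ in one place, and it shows that the maximal response can move beyond the scatter with the group at this position. As far as these compounds go, whether a pyrrolidin-1-yl or a dimethylamino group in the same place would give a larger or a smaller response stays open. Nothing measured here bears on why the response changes with this swap.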